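The source may report more compounds than this note shows. Statements on the series, on what has been measured and on what is new or still open speak of the compounds shown alone.

Working notes on the series: in a functional assay on SK-BR-3 cells (Homo sapiens) for inhibition, read by MTT assay, with a stated time of 24 h (on this read-out lower numbers stand for stronger inhibition of growth and higher numbers for weaker inhibition of growth), compound 1 (`C=CCNC(=S)N/N=C/c1ccccn1`) gives 8100 nM, compound 2 (`S=C(NCc1ccccc1)N/N=C/c1ccccn1`) gives 4600 nM and compound 3 (`CCNC(=S)N/N=C/c1ccccn1`) gives 6300 nM, so compound 3 lies within the scatter of both others. Compound 4 (`S=C(N/N=C/c1ccccn1)N1CCCC1`) carries pyrrolidin-1-yl in place of ethylamino on a thiocarbonyl carbon. The measured steps that bear on this are a 1.3-fold lower number from compound 1 to compound 3 (0.11 log units; within the scatter), a 1.4-fold higher number from compound 2 to compound 3 (0.14 log units; within the scatter) and a 1.8-fold lower number from compound 1 to compound 2 (0.25 log units; within the scatter), all within the scatter. None of them introduces a ring at this place or removes a hydrogen-bond donor, so the guidance is limited and the range is kept wide. In this assay, no step beyond the scatter is expected. The estimate means a 1.8-fold lower number from compound 3 to compound 4 (0.26 log units; within the scatter), an expected step in the lower direction. For compound 4 the estimated value is 3500 nM, with an expected range of 700 nM to 9000 nM.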

Compound 4, concentration for 50% growth inhibition: 4300 nM
The estimate for compound 4 lay 1.2-fold (0.09 log units) below the measured number; measured number inside the range.
By their numbers in this assay, from the lowest: compounds 4, 2, 3 and 1 (each within the scatter of the next).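

In this assay, pyrrolidin-1-yl on the thiocarbonyl carbon gives a 1.5-fold lower number from compound 3 to compound 4 (0.17 log units; within the scatter), and against allylamino it gives a 1.9-fold lower number from compound 1 to compound 4 (0.28 log units; within the scatter). Unlike the earlier chain changes, this change adds a ring and removes the hydrogen-bond donor at this place, yet both steps stay within the scatter. No measurement at hand accounts for this result.

From the compounds shown here alone, the ring and the loss of the donor change together in compound 4, so their separate contributions remain open. Dimethylamino on the thiocarbonyl carbon would separate them, and morpholin-4-yl would add a second ring hetero atom.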